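The source may hold more compounds than are shown below. What is called first, only, known or untested is meant among the compounds shown, and "the series" means these compounds.

Measured in a functional assay on HCT-116 cells (Homo sapiens) for inhibition, read by CCK-8 assay, with a stated time of 48 h; a higher number here means a weaker inhibitor, a lower number a stronger inhibitor:

- compound 1 `COc1cc(-c2ccnc3cc(-c4cn(CO)c5ccccc45)nn23)cc(OC)c1OC`: 128 nM
- compound 2 `COc1cc(-c2ccnc3cc(-c4cccc(C)c4)nn23)cc(OC)c1OC`: 6150 nM

Compound 1 holds the lower of the two numbers, and the gap to compound 2 lies well beyond the scatter. Within the data shown here, these two compounds differ in more than one place, so their values give no measured step for a single change.

The next compound is compound 3 `COc1cc(-c2ccnc3cc(-c4cn(C(=O)OC(C)(C)C)c5ccccc45)nn23)cc(OC)c1OC`, not yet measured. It keeps the core of compound 1 and changes one group: tert-butoxycarbonyl in place of hydroxymethyl on an aromatic nitrogen. The change is tert-butoxycarbonyl in place of hydroxymethyl on an aromatic nitrogen. Among the measured compounds shown here, no measured pair isolates a change at this nitrogen, so the expectation is loose.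

Compound 1 at 128 nM is the lowest number in the series, and the only other reference, compound 2, sits higher at 6150 nM. A moderate move towards a weaker inhibitor, probably just beyond the scatter, is therefore expected rather than a gain. The estimated change is a 3.5-fold higher number from compound 1 to compound 3 (0.55 log units; beyond the scatter). Compound 3 is estimated at 450 nM, with an expected range of 120 nM to 2000 nM.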

Compound 3, half-maximal inhibitory concentration: 5720 nM
For compound 3 the middle estimate is 13-fold (1.10 log units) below the measured one; the whole stated range lies below it.
By their numbers in this assay, from the lowest: compound 1; then compounds 3 and 2 (each within the scatter of the next).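

In this assay, among these compounds, the group on the aromatic nitrogen has a large influence on the read-out: tert-butoxycarbonyl in place of hydroxymethyl gives a 45-fold higher number from compound 1 to compound 3 (1.65 log units; beyond the scatter), the first measured step at this position. This single change replaces a group of 2 heavy atoms with 1 hydrogen-bond donor by one of 7 heavy atoms with 0 hydrogen-bond donors and adds a carbonyl, so group size, donor count and the carbonyl all vary together and this one step cannot separate them. No measurement at hand accounts for the step.

The compounds shown leave open how a small methyl group, an acetyl group or the free nitrogen-hydrogen would read at this nitrogen, and therefore whether hydroxymethyl itself contributes to the low number of compound 1 at 128 nM or whether only the larger tert-butoxycarbonyl group moves the number. Also open, as far as these compounds go, is how a longer chain on this nitrogen, such as a hydroxyethyl chain or one ending in an amine, would read.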